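This account rests on a few compounds, and the source may have more. Where it says the series, first, only, none or still open, it means among the compounds named here.

In an ADME assay on cells (Fibroblast, Homo sapiens) for antiproliferative activity, with a stated time of 48 h (on this read-out lower numbers stand for stronger inhibition and higher numbers for weaker inhibition), two compounds that share one core have been measured so far, and neither gives a number. Compound 1 `CCN(CC)c1ccc(-c2cccc(C(F)(F)F)c2)nn1` carries diethylamino, and its result is a limit of the assay, > 25000 nM. Compound 2 `FC(F)(F)c1cccc(-c2ccc(N3CCCC3)nn2)c1` carries pyrrolidin-1-yl, and its result is also a limit, > 25000 nM. Compound 2 therefore has no exact position, and all that can be said of it is the limit of > 25000 nM in this assay, at which 2 of the 2 values shown sit. Among the compounds with values here, the only measured step is a step that the two limits leave unreadable from compound 1 to compound 2, so it offers no size to carry forward.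

Compound 3 `FC(F)(F)c1cccc(-c2ccc(Oc3ccccc3)nn2)c1` is the next to be tested, and it changes the same place on the core: phenoxy in place of pyrrolidin-1-yl on an aromatic carbon. Within the data shown here, no measured step shows what phenoxy does here, so any expectation in this assay remains loose. The expectation leans on compound 2, whose result is the limit > 25000 nM, and weak inhibition or another limit is expected. The estimated change is an at least 1.2-fold lower number from compound 2 to compound 3 (0.09 log units; that floor lies within the scatter), and it carries no firm direction. For compound 3 the expected value is 20000 nM, within an estimated range from 8000 nM to 40000 nM.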

Compound 3, half-maximal inhibitory concentration: > 25000 nM
Compound 3: only a limit was reported; the forecaster's own chance of this, stated with the estimate: 60%; middle value at least 1.2-fold (0.09 log units) from the limit.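

Compound 3, like compound 1 and compound 2, gives only a limit in this assay, so no step among these three compounds can be read: the limit of > 25000 nM in this assay, at which 3 of the 3 values shown sit.

The compounds shown leave open whether any group at this place on the shared core gives a measurable value, and how diethylamino, pyrrolidin-1-yl and phenoxy rank against one another.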